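The source may hold more compounds than are shown below. What is called first, only, known or untested is meant among the compounds shown, and "the series" means these compounds.

In a functional assay on NCI-H358 cells (Homo sapiens) for cytotoxicity, read by sulforhodamine B assay (on this read-out lower numbers stand for an effect already at smaller amounts and higher numbers for an effect only at larger amounts of compound), compound 1 `CCCCCCCCCCCCCCCCCCCCCCCCc1cn([C@@H](CO)[C@H](O)[C@H](O)CCCCCCCCCCCCCC)nn1` gives > 50000 nM, which is a limit of the assay and not a number. Among the compounds with values here, compound 2 `CCCCCCCCCCCCCC[C@@H](O)[C@@H](O)[C@H](CO)n1cc(CCC)nn1` gives 13200 nM, the only actual number so far. Compound 3 `CCCCCCCCCCCCCC[C@@H](O)[C@@H](O)[C@H](CO)n1cc(CCCC)nn1` differs from compound 2 by methyl in place of hydrogen on a saturated chain carbon, three bonds along the chain from an aromatic carbon, so propyl becomes butyl. Within the data shown here, no measured step shows what this change does, so the expected shift a 1.1-fold lower number from compound 2 to compound 3 (0.04 log units; within the scatter) in this assay is small, within the usual scatter, with no favoured direction. Compound 3 is estimated at 12000 nM, with an expected range from 6000 nM to 25000 nM.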

Compound 3, half-maximal effective concentration: 12900 nM
Compound 3: middle estimate off by 1.1-fold (0.03 log units), on the low side; the measured number falls inside the stated range.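

Within the data shown here, this is the first measured step at this position. In this assay going from propyl to butyl gives a 1.0-fold lower number from compound 2 to compound 3 (0.01 log units; within the scatter) and so one added methyl on a saturated chain carbon, three bonds along the chain from an aromatic carbon, leaves the read-out where it was. Compound 1 stays outside any such comparison, since its value is a limit and not a number: the limit of > 50000 nM in this assay, at which 1 of the 3 values shown sits.

Still open, from the compounds shown here alone, is whether a chain of middling length, such as octyl or dodecyl, keeps the number in place. Also open, going by these compounds, is how an amine or a carboxylic acid at the end of this chain would read.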